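One Stereocentre Inverted Among Four Stereoisomers

A few compounds are considered here, and "the series" means these few. Any claim that something is new, unique, unknown or untested is made for them only; others in the source may bear on it.

Three stereoisomers have been measured in a functional assay on HCT-116 cells (Homo sapiens) for inhibition, read by MTT assay, with a stated time of 72 h; on this read-out lower numbers stand for stronger inhibition and higher numbers for weaker inhibition. Compound 1 `CC1=NN(c2ccccc2)C(=O)[C@]12C(=O)C=CC[C@H]2c1cccc(C)c1` gives 9580 nM, compound 2 `CC1=NN(c2ccccc2)C(=O)[C@@]12C(=O)C=CC[C@H]2c1cccc(C)c1` gives 5820 nM and compound 3 `CC1=NN(c2ccccc2)C(=O)[C@@]12C(=O)C=CC[C@@H]2c1cccc(C)c1` gives 3800 nM. Compound 3 stands level with compound 2, with a 1.5-fold lower number from compound 2 to compound 3 (0.19 log units; within the scatter), and clear of compound 1, with a 2.5-fold lower number from compound 1 to compound 3 (0.40 log units; beyond the scatter).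

Compound 4 `CC1=NN(c2ccccc2)C(=O)[C@]12C(=O)C=CC[C@@H]2c1cccc(C)c1` has not yet been measured. Its difference from compound 3 is this: the two compounds have the same atoms and bonds and differ only in configuration as drawn: 1 of 2 stereo elements differ; a stereocentre at a saturated ring carbon is drawn R in compound 3 and S in compound 4. Within the data shown here, the closest precedent comes from compound 2, since the same stereocentre is inverted in a 1.6-fold lower number from compound 1 to compound 2 (0.22 log units; within the scatter). Read in reverse, that small step points to a modest rise in the number. Compound 1, at 9580 nM, leads to the same region when the other inversion, a 1.5-fold lower number from compound 2 to compound 3 (0.19 log units; within the scatter), is applied to it. A small upward change in this assay is therefore expected, probably no larger than the scatter. The expected step is a 1.6-fold higher number from compound 3 to compound 4 (0.20 log units; within the scatter). The estimate for compound 4 is 6000 nM, with an expected range from 3500 nM to 10000 nM.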

Compound 4, half-maximal inhibitory concentration: 5490 nM
Compound 4: the middle estimate sits 1.1-fold (0.04 log units) above what was measured, and the stated range covers the measured number.
By their numbers in this assay, from the lowest: compounds 3, 4, 2 and 1 (each within the scatter of the next, the first and the last beyond it).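

With the fourth stereoisomer in place, this assay shows that inverting this stereocentre at a saturated ring carbon stays within the scatter, with a 1.4-fold higher number from compound 3 to compound 4 (0.16 log units; within the scatter). Inverting both stereocentres leaves one mirror-image pair level, with a 1.1-fold lower number from compound 2 to compound 4 (0.03 log units; within the scatter), while the other pair gives a 2.5-fold lower number from compound 1 to compound 3 (0.40 log units; beyond the scatter), the only step among these four stereoisomers that lies beyond the scatter. The remaining single inversion, a 1.7-fold lower number from compound 1 to compound 4 (0.24 log units; within the scatter), also falls within the scatter, so every single inversion among these compounds stays within it, and only inverting both stereocentres of compound 1 gives a step beyond it.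

These compounds differ in configuration alone, so they leave open how the read-out would respond to a change of atoms on the shared core, such as an added amine or carboxylic acid. They also leave open whether these small differences would persist in other cell lines.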